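This account rests on a few compounds, and the source may have more. Where it says the series, first, only, none or still open, it means among the compounds named here.

Measured in a functional assay on MCF7 cells (Homo sapiens) for inhibition, with a stated time of 96 h; on this read-out lower numbers stand for stronger inhibition and higher numbers for weaker inhibition:
compound 1 `COc1cc(C(=O)c2cn(-c3cccc(C)c3)cc2-c2ccco2)cc(OC)c1OC` gives 23 nM here
compound 2 `COc1cc(C(=O)c2cn(-c3ccc(C)cc3)cc2-c2ccco2)cc(OC)c1OC` gives 22 nM here

Compound 2 stands level with compound 1, the two values lying within the scatter of each other. Within the data shown here, the one measured step is a 1.0-fold lower number from compound 1 to compound 2 (0.02 log units; within the scatter) and it concerns only the group on the aromatic nitrogen, so it gives no guide to the next change. Compound 3 `COc1cc(C(=O)c2cn(-c3ccc(C)cc3)cc2-c2ccncc2)cc(OC)c1OC` carries pyridin-4-yl in place of furan-2-yl on an aromatic carbon, counted as pyridin-4-yl in place of furan-2-yl on an aromatic carbon in full. Among the measured compounds shown here, no measured step covers this place, so the expectation is loose, and a move to a higher number in this assay is expected. The estimated step is a 3.6-fold higher number from compound 2 to compound 3 (0.56 log units; beyond the scatter) with wide uncertainty. Compound 3 is expected at 80 nM with an estimated range from 15 nM to 450 nM on this read-out.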

Compound 3, half-maximal inhibitory concentration: 9 nM
The estimate for compound 3 lay 8.9-fold (0.95 log units) above the measured number, and the stated range ends above it.
By their numbers in this assay, from the lowest: compound 3; then compounds 2 and 1 (each within the scatter of the next).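

The position on an aromatic carbon of the five-membered aromatic ring with 1 nitrogen responds to a change of ring: in this assay, pyridin-4-yl in place of furan-2-yl gives a 2.4-fold lower number from compound 2 to compound 3 (0.39 log units; beyond the scatter), a shift in the favourable direction. Among these compounds, compounds 1 and 2 varied only the group on the ring nitrogen, so this is the first reading at this second position, and it shows that furan-2-yl is not required for inhibition here. Nothing on hand accounts for the gain.

With a single replacement at this position, ring size and the place of the ring nitrogen cannot be told apart, and phenyl, pyridin-3-yl or thiophen-2-yl would separate them. Also open, as far as these compounds go, are whether an amine or a carboxylic acid on the pyridine ring keeps the number, and whether the step carries over to the 3-methylphenyl group of compound 1.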